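The compounds below may be only part of what the source reports. "The series", "measured", "known", "first", "only" and "open" are said of these compounds alone.

Working notes on the series. Compound 3 `COc1ccc(-n2c(CCc3ccccc3)nnc2[C@H](NC(=O)Cc2ccccn2)c2c[nH]c3ccccc23)c(OC)c1` gives 120 nM in an in vitro assay on LLC-PK1 cells for displacement of a labelled ligand from growth hormone secretagogue receptor type 1 (Homo sapiens) (on this read-out lower numbers stand for stronger inhibition and higher numbers for weaker inhibition), and so stands highest of the three numbers recorded. Compound 1 `COc1ccc(-n2c(CCc3ccccc3)nnc2[C@H](NC(=O)c2ccccn2)c2c[nH]c3ccccc23)c(OC)c1` gives 33 nM and compound 2 `COc1ccc(Cn2c(CCc3ccccc3)nnc2[C@H](NC(=O)c2ccccn2)c2c[nH]c3ccccc23)cc1` gives 0.7 nM. Two single-point steps are known: a 3.6-fold higher number from compound 1 to compound 3 (0.56 log units; beyond the scatter), and a 47-fold lower number from compound 1 to compound 2 (1.67 log units; beyond the scatter).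

The next compound, compound 4 `COc1ccc(Cn2c(CCc3ccccc3)nnc2[C@H](NC(=O)Cc2ccccn2)c2c[nH]c3ccccc23)cc1`, differs from compound 3 only in that (4-methoxybenzyl in place of 2,4-dimethoxyphenyl on an aromatic nitrogen). Within the data shown here, this is the same exchange as the one already seen between compound 1 and compound 2, so the step of a 47-fold lower number from compound 1 to compound 2 (1.67 log units; beyond the scatter) is the one that bears directly on it; the step of a 3.6-fold higher number from compound 1 to compound 3 (0.56 log units; beyond the scatter) only places compound 3 as the starting point. A large step toward a lower number is therefore expected in this assay, of roughly the size seen from compound 1 to compound 2, allowing for the scatter of a single comparison.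

Compound 4 is accordingly expected to give about 2.5 nM in this assay, within a range of 0.8 nM to 8 nM. The expected step is a 48-fold lower number from compound 3 to compound 4 (1.68 log units; beyond the scatter).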

Compound 4, half-maximal inhibitory concentration: 3 nM
Compound 4: the middle estimate sits 1.2-fold (0.08 log units) below what was measured; measured number inside the range.
By their numbers in this assay, from the lowest: compound 2; then compound 4; then compound 1; then compound 3.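

The exchange of 2,4-dimethoxyphenyl for 4-methoxybenzyl on the aromatic nitrogen now recurs on a second core, as a 40-fold lower number from compound 3 to compound 4 (1.60 log units; beyond the scatter), and its size holds with either amide side chain: the same change on two cores in this assay, a 47-fold lower number (1.67 log units; beyond the scatter) from compound 1 to compound 2 and a 40-fold lower number (1.60 log units; beyond the scatter) from compound 3 to compound 4, 1.2-fold (0.07 log units) apart, within the scatter of two such steps. The exchange of pyridin-2-yl for (pyridin-2-yl)methyl on the carbonyl carbon also recurs with the other nitrogen substituent in place, as a 4.3-fold higher number from compound 2 to compound 4 (0.63 log units; beyond the scatter): the same change on two cores in this assay, a 3.6-fold higher number (0.56 log units; beyond the scatter) from compound 1 to compound 3 and a 4.3-fold higher number (0.63 log units; beyond the scatter) from compound 2 to compound 4, 1.2-fold (0.07 log units) apart, within the scatter of two such steps. In these four compounds, each change therefore shifts the number by a similar amount whichever form the other position takes, and none of the four goes against this.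

The exchange alters the link to the aromatic ring and the number of methoxy groups at once, and the compounds shown do not separate the two. Also open, from the compounds shown here alone, is whether this independence extends to a benzyl group without methoxy on the nitrogen, or to a carboxylic acid or an amine in place of the pyridine.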